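The source may report more compounds than this note shows. Statements on the series, on what has been measured and on what is new or still open speak of the compounds shown alone.

Compounds 1, 2 and 3 share one core and differ only in the group on a carbonyl carbon. In an ADME assay on microsomes from liver (Homo sapiens) for metabolic stability, read by LC-MS, using NADPH, with a stated time of 30 min, tested at 0.1 uM (on this read-out higher numbers stand for a more stable compound and lower numbers for a less stable compound), compound 1 `C[C@@]1(c2cc(NC(=O)c3cnc(OCF)cn3)ccc2F)C=C(CF)OC(N)=N1` gives 86%, compound 2 `Cc1cc(C#N)cnc1C(=O)Nc1ccc(F)c([C@]2(C)C=C(CF)OC(N)=N2)c1` gives 63%, and compound 3 `C[C@@]1(c2cc(NC(=O)c3coc(CF)n3)ccc2F)C=C(CF)OC(N)=N1` gives 76%. Compound 3 cannot be told apart from compound 1, as a number 10 percentage points lower from compound 1 to compound 3 (within the scatter) shows, but it clearly stands above compound 2. The two ends of the set are separated by a number 23 percentage points lower from compound 1 to compound 2 (beyond the scatter).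

The unmeasured compound 4 `COc1cc(C#N)cnc1C(=O)Nc1ccc(F)c([C@]2(C)C=C(CF)OC(N)=N2)c1` changes the group on the carbonyl carbon again: 5-cyano-3-methoxypyridin-2-yl in place of 2-(fluoromethyl)-1,3-oxazol-4-yl on a carbonyl carbon. The best guide is compound 2, whose 5-cyano-3-methylpyridin-2-yl group has methyl where the incoming group has methoxy. The measured step of a number 13 percentage points higher from compound 2 to compound 3 (beyond the scatter) is a modest one and is close to the same swap run in the opposite direction. Among the measured compounds shown here, a downward step of similar size is therefore expected in this assay, although no measured pair here compares methoxy with methyl directly. The estimated change is a number 11 percentage points lower from compound 3 to compound 4 (beyond the scatter). For compound 4 the estimated value is 65%, with an expected range from 50% to 80%.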

Compound 4, percent of the compound remaining: 85%
Estimate against measurement, compound 4: 20 percentage points below; the whole stated range lies below it.
By their numbers in this assay, from the lowest: compound 2; then compounds 3, 4 and 1 (each within the scatter of the next).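

Swapping methyl for methoxy on an aromatic carbon is the only difference in one pair, and it gives a number 22 percentage points higher from compound 2 to compound 4 (beyond the scatter) in this assay, so this single small substituent clearly moves the read-out. The other two steps, a number 9 percentage points higher from compound 3 to compound 4 (within the scatter) and a number 1 percentage points lower from compound 1 to compound 4 (within the scatter), both lie within the scatter, so on this read-out 5-cyano-3-methoxypyridin-2-yl cannot be told apart from 2-(fluoromethyl)-1,3-oxazol-4-yl or 5-(fluoromethoxy)pyrazin-2-yl. Nothing available here explains why methoxy and methyl differ in this way.

The compounds shown offer only methyl and methoxy as this substituent, so it remains open how an ethoxy group, a hydroxyl group or a chlorine atom in the same place would read. Also open, going by these compounds, is whether the methoxy step would hold without the nitrile.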